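Cyclobutyl in place of pyrazin-2-yl on an oxygen

A few compounds are considered here, and "the series" means these few. Any claim that something is new, unique, unknown or untested is made for them only; others in the source may bear on it.

In an ADME assay on the whole organism (Rattus norvegicus) for pharmacokinetics, using cassette dosing, at a dose of 1 mg/kg by the oral route (on this read-out lower numbers stand for lower oral bioavailability and higher numbers for higher oral bioavailability), compound 1 `CC(C)Oc1ccc(/N=c2\[nH]c(=O)n(C[C@@H](O)CO)c(=O)n2Cc2ccc(Cl)cc2)cc1Cl` gives 63% and compound 2 `C[C@@H](Cn1c(=O)[nH]/c(=N\c2ccc(Oc3cnccn3)cc2)n(Cc2ccc(Cl)cc2)c1=O)C(=O)O` gives 56.5% with the two values within the usual scatter of each other. Relative to compound 2, compound 3 `C[C@@H](Cn1c(=O)[nH]/c(=N\c2ccc(OC3CCC3)cc2)n(Cc2ccc(Cl)cc2)c1=O)C(=O)O` carries cyclobutyl in place of pyrazin-2-yl on an oxygen on an aromatic ring. Among the measured compounds shown here, no measured pair shows this change alone, so no step beyond the scatter is expected in this assay in either direction. The estimated step (a number 1.5 percentage points lower from compound 2 to compound 3 (within the scatter)) is expected to stay within that scatter. In this assay the estimate for compound 3 is 55% (expected range 35% to 73%).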

Compound 3, oral bioavailability: 54.3%
For compound 3 the middle estimate is 0.7 percentage points above the measured one; the measured number falls inside the stated range.
By their numbers in this assay, from the lowest: compounds 3, 2 and 1 (each within the scatter of the next).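

In this assay, the exchange of pyrazin-2-yl for cyclobutyl on an oxygen on an aromatic ring gives (a number 2.2 percentage points lower from compound 2 to compound 3 (within the scatter)). This position therefore accepts a four-membered non-aromatic ring of carbon only in place of a six-membered aromatic ring with 2 hetero atoms, with no step beyond the scatter. No evidence available here bears on this result. The compounds shown leave open how an amine or a longer alkyl chain on this oxygen would read in this assay. They also leave open whether the same exchange gives a similar step when the carboxylic acid side chain of compound 3 is replaced by another group.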